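The source may hold more compounds than are shown below. What is called first, only, known or untested is meant among the compounds shown, and "the series" means these compounds.

Within the data shown here, in a functional assay on HL-60 cells (Homo sapiens) for antiproliferative activity, read by sulforhodamine B assay, with a stated time of 72 h (a lower number here means a stronger inhibitor, a higher number a weaker inhibitor), compound 1 `S=C(NCc1ccccc1)N/N=C/c1ccc2ccccc2n1` gives 21900 nM, the only value here that is an actual number. Compound 2 `NC(=S)N/N=C/c1nc2ccccc2s1` gives > 100000 nM, which is a limit of the assay. Compound 3 `Cc1ccc(NC(=O)N/N=C/c2ccc3ccccc3n2)cc1` gives > 100000 nM, also a limit. The set therefore rests heavily on (the limit of > 100000 nM in this assay, at which 2 of the 3 values shown sit). Compound 4 `S=C(N/N=C/c1ccc2ccccc2n1)Nc1ccccc1Br` has 2-bromophenyl in place of benzyl on an amide-type nitrogen. Among the measured compounds shown here, no measured pair isolates this change, so the expectation can only start from compound 1 at 21900 nM. The expected change in this assay is a modest gain in inhibition, estimated as a 2.4-fold lower number from compound 1 to compound 4 (0.39 log units; beyond the scatter), and it is held with wide uncertainty. For compound 4 the estimated value is 9000 nM, with an expected range of 1800 nM to 45000 nM.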

Compound 4, half-maximal inhibitory concentration: > 100000 nM
Compound 4: only a limit was reported; the forecaster's own chance of this, stated with the estimate: 15%; middle value at least 11-fold (1.04 log units) away from the limit.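

In this assay, among these compounds, 2-bromophenyl in place of benzyl on the amide-type nitrogen gives an at least 4.5-fold higher number from compound 1 to compound 4 (0.65 log units; beyond the scatter), so the first direct reading at this place shows a loss of inhibition. Compound 4 gives > 100000 nM, which is a limit and not a number, so only the minimum size of this step is known. Compound 1 remains the only compound with a measured number: the limit of > 100000 nM in this assay, at which 3 of the 4 values shown sit.

The compounds shown leave open whether the loss follows the bromine or the change from benzyl to an aryl group. Plain phenyl, 2-bromobenzyl or a longer chain such as phenethyl on this nitrogen could separate these readings.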